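The source may hold more compounds than are shown below. What is called first, only, known or untested is meant among the compounds shown, and "the series" means these compounds.

Measured so far:
compound 1, `COc1ccc(C2N=C(SCc3ccccc3Cl)NC(C)=C2C(=O)Nc2ccc(F)cc2)cc1OC`, giving 30.3% in a functional assay on the whole organism (artery, strain albino) with Rattus norvegicus as the target, with a stated time of 600 min, at a dose of 10 mg/kg by the oral route; a lower number here means less inhibition, a higher number more inhibition at the dose given (going by the name of the read-out);
compound 2, `COc1ccc(C2N=C(SCc3cccc(Cl)c3)NC(C)=C2C(=O)Nc2ccc(F)cc2)cc1OC`, giving 17.4% in this assay;
compound 3, `COc1ccc(C2N=C(SCc3ccccc3Cl)NC(C)=C2C(=O)Nc2ccc(Br)cc2)cc1`, giving 13.3% in this assay.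

Compound 4, `COc1ccc(C2N=C(SCc3cccc(Cl)c3)NC(C)=C2C(=O)Nc2ccc(Br)cc2)cc1`, has not been measured. The change from compound 1 to compound 2 is 3-chlorophenyl in place of 2-chlorophenyl on a saturated chain carbon bound to a sulfur, and it made a step of a number 12.9 percentage points lower from compound 1 to compound 2 (beyond the scatter). The difference between the core of compound 3 and the core of compound 1 is not broken down here. The change from compound 3 to compound 4 is 3-chlorophenyl in place of 2-chlorophenyl on a saturated chain carbon bound to a sulfur, the same change at the same place. Compound 3 and compound 2 lie within the scatter of each other. A step of a number 8.3 percentage points lower from compound 3 to compound 4 (within the scatter) is expected for compound 4, because the earlier step was a number 12.9 percentage points lower from compound 1 to compound 2 (beyond the scatter). Compound 4 is therefore estimated at 5%, expected to fall between 0% and 16%.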

Compound 4, a percentage reported as inhibition, in the whole organism at one dose (the size of the read-out at that dose, not a potency): 32.8%
For compound 4 the middle estimate is 27.8 percentage points below the measured one; the measured number lies above the stated range.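

In this assay, putting 3-chlorophenyl in place of 2-chlorophenyl gave a number 19.5 percentage points higher from compound 3 to compound 4 (beyond the scatter), so this change did not carry over from one core to the other: the same change on two cores in this assay, a number 12.9 percentage points lower (beyond the scatter) from compound 1 to compound 2 and a number 19.5 percentage points higher (beyond the scatter) from compound 3 to compound 4, 32.4 percentage points apart, beyond the scatter of two such steps The two pairs show that the result of this change depends on the core it sits on, with the direction reversed here. They do not show which part of the core matters, as the difference between the two cores is not broken down, and they cannot predict the step on a third core.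

The compounds shown leave open how a plain benzyl without chlorine, or a benzyl carrying an amine or a carboxylic acid, would behave on either core in this assay.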